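Aryl amide swap on a weakly active diarylaminopyrimidine series

This account rests on a few compounds, and the source may have more. Where it says the series, first, only, none or still open, it means among the compounds named here.

Compound 3 `O=C(Nc1ccc(C(F)(F)F)cc1)c1cccc(Nc2ncc(F)c(Nc3ccc(F)cc3)n2)c1` is one of three amides on a shared core that were run in a functional assay on DU-145 cells (Homo sapiens) for antiproliferative activity, read by sulforhodamine B assay, with a stated time of 3 days; on this read-out lower numbers stand for stronger inhibition of growth and higher numbers for weaker inhibition of growth. Compound 1 `O=C(NCCO)c1cccc(Nc2ncc(F)c(Nc3ccc(F)cc3)n2)c1` gives 13400 nM there, and compound 2 `Cn1ccnc1NC(=O)c1cccc(Nc2ncc(F)c(Nc3ccc(F)cc3)n2)c1` gives 15100 nM. Compound 3 is known only through a limit of the assay: in this assay compound 3 gives > 10000 nM. Within the data shown here, for that reason the steps a step that the limit leaves unreadable from compound 1 to compound 3 and a step that the limit leaves unreadable from compound 2 to compound 3 cannot be sized, as the limit of > 10000 nM in this assay, at which 1 of the 3 values shown sits, shows, and the one readable step, a 1.1-fold higher number from compound 1 to compound 2 (0.05 log units; within the scatter), stays inside the scatter. The next compound, compound 4 `O=C(Nc1ccccn1)c1cccc(Nc2ncc(F)c(Nc3ccc(F)cc3)n2)c1`, differs from compound 3 in a single place: pyridin-2-yl in place of 4-(trifluoromethyl)phenyl on an amide-type nitrogen. Among the measured compounds shown here, nothing measured so far separates the arylamide from the hydroxyethyl and imidazolyl amides by a readable amount, so no direction beyond the scatter can be expected from this change, and weak activity remains the likeliest outcome. The estimate for compound 4 is 15000 nM, expected to fall between 5000 nM and 40000 nM. That estimate would mean a step that the limit leaves unreadable from compound 3 to compound 4, which is an expectation rather than a measurement.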

Compound 4, concentration for 50% growth inhibition: 15100 nM
The estimate for compound 4 lay 1.0-fold (0.00 log units) below the measured number; measured number inside the range.
By their numbers in this assay, from the lowest: compounds 1, 2 and 4 (each within the scatter of the next).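

In this assay, pyridin-2-yl on the amide-type nitrogen gives no change at the digits printed from compound 2 to compound 4 (within the scatter), and against the 2-hydroxyethyl amide it gives a 1.1-fold higher number from compound 1 to compound 4 (0.05 log units; within the scatter). The readable part of the series now holds three different groups at this place, one open chain and two aromatic rings with hetero atoms, and none of them separates from the others by more than the scatter. Compound 3 stays outside this comparison, and every step that involves it cannot be read: the limit of > 10000 nM in this assay, at which 1 of the 4 values shown sits.

Still open, from the compounds shown here alone, is whether a carboxylic acid, a morpholine or a longer chain ending in a dimethylamino group on this amide-type nitrogen would move the number beyond the scatter. The compounds shown also leave open whether any change elsewhere on the shared core would do so.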